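Swapping Chloro for Methoxy: What Compound 3 Might Show

This account rests on a few compounds, and the source may have more. Where it says the series, first, only, none or still open, it means among the compounds named here.

Of the compounds shown here, two have so far been measured in a functional assay on HSC-3 cells (Homo sapiens) for cytotoxicity; a lower number here means that less compound is tolerated, a higher number that more compound is tolerated. Compound 1 `COc1ccc(/C=C2\CCC/C(=C\c3ccc([N+](=O)[O-])cc3)C2=O)cc1OC` gives 4400 nM, and compound 2 `O=C1/C(=C/c2ccc(Cl)cc2)CCC/C1=C\c1ccc([N+](=O)[O-])cc1` gives 4600 nM. Compound 2 holds the highest of the two numbers, yet its gap to compound 1 lies within the scatter, so the two values show no difference that can be trusted.

Compound 3 `COc1ccc(/C=C2\CCC/C(=C\c3ccc([N+](=O)[O-])cc3)C2=O)cc1` has not yet been measured. It differs from compound 2 by methoxy in place of chloro on an aromatic carbon. For the measured compounds named here, no measured pair isolates this change, so its effect is unknown. Compound 1, which also carries methoxy groups, sits within the scatter of compound 2 in this assay, and that is the only hint available.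

The step expected in this assay is a 1.0-fold lower number from compound 2 to compound 3 (0.01 log units; within the scatter), small and in no clear direction beyond the scatter. Compound 3 is estimated at 4500 nM, with a range from 2300 nM to 9000 nM.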

Compound 3, half-maximal cytotoxic concentration: > 400000 nM
Compound 3: no number, only a limit; the forecaster's own chance of this, stated with the estimate: 5%; middle value at least 88-fold (1.94 log units) away from the limit.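

Compound 3 gives > 400000 nM in this assay, which is a limit of the assay and not a number, and it is the only such value here: the limit of > 400000 nM in this assay, at which 1 of the 3 values shown sits.

At this aromatic carbon, para to a large group, going from 4-chlorophenyl to 4-methoxyphenyl is far from a neutral swap, with an at least 86-fold higher number from compound 2 to compound 3 (1.93 log units; beyond the scatter). Hydrogen in place of methoxy on an aromatic carbon brings an at least 90-fold higher number from compound 1 to compound 3 (1.95 log units; beyond the scatter), so the second methoxy group carries much weight in this series, something the two earlier values could not reveal.

The limit leaves the true size of both steps open. As far as these compounds go, it is also open whether an amine, a hydroxyl or a fluorine at the same carbon would stay close to compound 2 or move as far as methoxy does.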